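Cytotoxicity Step from Compound 2 to Compound 3

The compounds below may be only part of what the source reports. "The series", "measured", "known", "first", "only" and "open" are said of these compounds alone.

Compound 1 `CCOc1ccc(CN(Cc2ccc(C(C)(C)C)cc2)Cc2cc3cc(C)ccc3[nH]c2=O)cc1` and compound 2 `CSc1ccc(CN(Cc2ccc(C(C)(C)C)cc2)Cc2cc3cc(C)ccc3[nH]c2=O)cc1` share a core and differ in one place. In a toxicity assay on MDCK cells (Canis lupus familiaris) for cytotoxicity, read by crystal violet staining, with a stated time of 48 h (on this read-out lower numbers stand for higher toxicity in this test and higher numbers for lower toxicity in this test), compound 1 gives > 10000 nM, which is a limit of the assay rather than a number. In this assay compound 2 gives > 5000 nM, again a limit of the assay. The step that the two limits leave unreadable from compound 1 to compound 2 cannot be read, since both ends sit at limits the limit of > 10000 nM in this assay, at which 1 of the 2 values shown sits, and (the limit of > 5000 nM in this assay, at which 1 of the 2 values shown sits). Within the data shown here, compound 2 therefore stands at a limit, and the one other value in this set is also a limit. Compound 3 `Cc1ccc2[nH]c(=O)c(CN(Cc3ccc(C(C)(C)C)cc3)[C@@H](C)c3ccc(F)cc3)cc2c1` is not yet measured; it differs from compound 2 by 1-(4-fluorophenyl)ethyl in place of 4-(methylsulfanyl)benzyl on an amine nitrogen. Among the measured compounds shown here, no measured step touches this change, and the only measured step is unreadable, so no direction can be drawn from the data. Compound 3 is expected to sit at a similar level, with an estimated step that the limit leaves unreadable from compound 2 to compound 3 within the scatter. The estimate for compound 3 in this assay is 8000 nM, ranging from 3000 nM to 30000 nM.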

Compound 3, half-maximal cytotoxic concentration: > 5000 nM
Compound 3 was reported as a limit; the forecaster's own chance of this, stated with the estimate: 70%; the middle value does not contradict the limit.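

In this assay compound 3 gives > 5000 nM, again a limit of the assay. The steps to compound 3 from compound 1 and from compound 2 therefore cannot be read. The compounds shown leave open whether these three compounds differ at all in this read-out, since all three values are limits.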